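The source may hold more compounds than are shown below. What is called first, only, known or untested is meant among the compounds shown, and "the series" means these compounds.

Measured compounds in a functional assay on MCF7 cells (Homo sapiens) for inhibition, read by MTT assay, with a stated time of 72 h; a lower number here means a stronger inhibitor, a higher number a weaker inhibitor:
compound 1 `CN(C(=O)NC(=O)c1cccc(C(F)(F)F)c1)c1nc(C(F)(F)F)c(C(=O)N/N=C/c2ccc(C(F)(F)F)cc2)s1`, 6.5 ug/mL
compound 2 `CN(C(=O)NC(=O)c1cccc(C(F)(F)F)c1)c1nc(C(F)(F)F)c(C(=O)N/N=C/c2ccccc2C(F)(F)F)s1`, 7.69 ug/mL
compound 3 `CN(C(=O)NC(=O)c1ccc(Cl)c(Cl)c1)c1nc(C(F)(F)F)c(C(=O)N/N=C/c2cccc([N+](=O)[O-])c2)s1`, 7.51 ug/mL

Compound 2 stands alongside the other two: against compound 1 the step of a 1.2-fold higher number from compound 1 to compound 2 (0.07 log units; within the scatter) is within the scatter, and compound 3 gives a number that compound 2 cannot be told apart from either. Across the three measured compounds no difference exceeds the scatter, so the shared core appears to tolerate the changes seen so far on either aryl end without a resolvable shift.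

Compound 4 `CN(C(=O)NC(=O)c1cccc([N+](=O)[O-])c1)c1nc(C(F)(F)F)c(C(=O)N/N=C/c2ccccc2C(F)(F)F)s1` is the next point. For the measured compounds named here, the change from compound 2 is nitro in place of trifluoromethyl on an aromatic carbon; it touches the acyl aryl of the acylurea side, where none of the measured compounds differ from one another in this way. Going by the values given here, the only single-point step available, a 1.2-fold higher number from compound 1 to compound 2 (0.07 log units; within the scatter), concerns the other aryl end and was within the scatter. Compound 3, which carries a nitro group on its hydrazone aryl and a different acyl aryl, likewise sits within the scatter of compound 2. Among the compounds with values here, no measured step therefore gives grounds to expect a shift beyond the scatter in this assay for compound 4.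

Compound 4 is estimated at 7.5 ug/mL, with a range of 3.5 ug/mL to 16 ug/mL, which means an expected step of a 1.0-fold lower number from compound 2 to compound 4 (0.01 log units; within the scatter).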

Compound 4, half-maximal inhibitory concentration: 4.73 ug/mL
Estimate against measurement, compound 4: 1.6-fold (0.20 log units) above, within the range that was stated.
By their numbers in this assay, from the lowest: compounds 4, 1, 3 and 2 (each within the scatter of the next).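

In this assay, for the compounds shown here, the exchange of 3-(trifluoromethyl)phenyl for 3-nitrophenyl on the carbonyl of the acylurea side gives the first single-place reading at this end of the series: a 1.6-fold lower number from compound 2 to compound 4 (0.21 log units; within the scatter). Trifluoromethyl and nitro therefore cannot be told apart on this aromatic carbon, even though a group with no hydrogen-bond acceptors gives way to one that has them, and this end now matches the other aryl end, where a 1.2-fold higher number from compound 1 to compound 2 (0.07 log units; within the scatter) is also unresolved. Nothing measured alongside these numbers offers an explanation for the result, and any reading of it stays limited to the assay numbers themselves.

Still open, going by these compounds, is whether an amine, a carboxylic acid or a nitrile on the same aromatic carbon would produce a step beyond the scatter, since the two groups compared here leave the number unresolved and mark out only a narrow part of what this position could hold. Going by these compounds alone, also open is whether the exchange of trifluoromethyl for nitro reads the same with a hydrazone aryl other than 2-(trifluoromethyl)phenyl, as this single pair is the only direct comparison at this position.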